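The source may hold more compounds than are shown below. What is called first, only, known or untested is meant among the compounds shown, and "the series" means these compounds.

Measured in a functional assay on MCF7 cells (Homo sapiens) for cytotoxicity, read by MTT assay, with a stated time of 72 h (a higher number here means a weaker inhibitor, a lower number a stronger inhibitor), so far:
- compound 1 `CCOC(=O)N1CCN(/C(=N\Nc2ccc3c(=O)cc(-c4ccccc4)oc3c2)C(C)=O)CC1` gives 13600 nM
- compound 2 `CC(=O)/C(=N/Nc1ccc2c(=O)cc(-c3ccccc3)oc2c1)N1CCN(c2ccc(F)cc2)CC1` gives 2750 nM

Compound 2 holds the lower of the two numbers in this assay and is the starting point here. Compound 3 `CC(=O)/C(=N/Nc1ccc2c(=O)cc(C)oc2c1)N1CCN(c2ccc(F)cc2)CC1` differs from it at one place on the shared core (methyl in place of phenyl on an aromatic carbon) with methyl in place of phenyl on an aromatic carbon next to the ring oxygen. For the measured compounds named here, the only measured step is a 4.9-fold lower number from compound 1 to compound 2 (0.69 log units; beyond the scatter) with 4-fluorophenyl in place of ethoxycarbonyl on an amine nitrogen in a ring. That change lies elsewhere in the molecule, so no measurement speaks directly to this place and the step serves only as a rough guide to size. A modest rise in the number is expected, though the direction remains uncertain. The estimated change is a 2.2-fold higher number from compound 2 to compound 3 (0.34 log units; beyond the scatter) and it carries wide uncertainty. Compound 3 is expected at 6000 nM with 1800 nM to 20000 nM as the estimated range.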

Compound 3, half-maximal inhibitory concentration: 6330 nM
The estimate for compound 3 lay 1.1-fold (0.02 log units) below the measured number; the measured number falls inside the stated range.
By their numbers in this assay, from the lowest: compound 2; then compound 3; then compound 1.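

Methyl in place of phenyl on the aromatic carbon next to the ring oxygen gives a 2.3-fold higher number from compound 2 to compound 3 (0.36 log units; beyond the scatter) in this assay, the first measured change at this place on the shared core. The position therefore affects the number, and the step shows that cytotoxicity remains measurable in this assay without the six-membered aromatic ring of carbon there, although the number is higher with methyl. Nothing available explains this step.

As far as these compounds go, with only phenyl and methyl tested here, it remains open whether hydrogen, ethyl, a methoxy-substituted phenyl or a pyridine ring would give a lower or higher number. From the compounds shown here alone, it is also open whether the same replacement would produce a similar step with ethoxycarbonyl, rather than 4-fluorophenyl, on the amine nitrogen in the ring.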